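The compounds below may be only part of what the source reports. "The series", "measured", "known", "first", "only" and "open" are said of these compounds alone.

On these data alone, in a functional assay on HOP-92 cells (Homo sapiens) for cytotoxicity, read by sulforhodamine B assay, with a stated time of 48 h (on this read-out higher numbers stand for lower toxicity in this test and lower numbers for higher toxicity in this test), three compounds have been measured and a fourth is still open. Compound 1 `ClCc1ccc(Cn2cnc3c(Cl)ncnc32)cc1` gives > 100000 nM, which is a limit of the assay and not a number. Compound 2 `Nc1nc(Cl)c2ncn(Cc3ccc(CCl)cc3)c2n1` gives > 100000 nM, again a limit of the assay rather than a number. Going by the values given here, compound 3 `ClCc1ccccc1Cn1cnc2c(Cl)ncnc21` is the only one with a number: in this assay compound 3 gives 21400 nM. The difference between the cores of compound 1 and compound 3 is not broken down here.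

The change from compound 1 to compound 2 is amino in place of hydrogen on an aromatic carbon. The step that the two limits leave unreadable from compound 1 to compound 2 cannot be read because both values sit at the limit of > 100000 nM in this assay, at which 2 of the 3 values shown sit. Compound 4 `Nc1nc(Cl)c2ncn(Cc3ccccc3CCl)c2n1` differs from compound 3 by amino in place of hydrogen on an aromatic carbon, the same change as from compound 1 to compound 2, made at a place described in the same words.

Among the compounds with values here, since the earlier step gives no size, the expectation for compound 4 rests on compound 3 alone, whose value of 21400 nM is the only number available. Compound 4 is expected to give about 30000 nM, with a likely range from 10000 nM to 100000 nM. The expected step of a 1.4-fold higher number from compound 3 to compound 4 (0.15 log units; within the scatter) is kept small, since the one earlier occurrence of the change leaves its size unreadable, and there is a real chance that compound 4 too will return only a limit.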

Compound 4, concentration lethal to 50% of the cells: > 100000 nM
Compound 4: only a limit was reported (the forecaster's own chance of this, stated with the estimate: 35%); middle value at least 3.3-fold (0.52 log units) away from the limit.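

In this assay, amino in place of hydrogen on an aromatic carbon of the core of compound 3 gives an at least 4.6-fold higher number from compound 3 to compound 4 (0.66 log units; beyond the scatter), so on this core the change moves the read-out towards lower toxicity in this test, by more than the usual scatter. This does not show that the change has the same size on the core of compound 1, since compound 1 and compound 2 both return only a limit of the assay, so that step cannot be read and the two occurrences cannot be compared. The full size of the new step also stays unknown, because the result for compound 4 is a limit of the assay and not a number: the limit of > 100000 nM in this assay, at which 3 of the 4 values shown sit.

The compounds shown leave open whether a methylamino or a methoxy group on the same aromatic carbon would raise the number as amino does on the core of compound 3. They also leave open whether amino would have a readable effect on a core that gives numbers on both sides of the change, which would allow a real measure of how well it carries over.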